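Compound 4: 4-hydroxy-3-methoxyphenyl replaces 3,5-dibromo-2-hydroxyphenyl

The compounds below may be only part of what the source reports. "The series", "measured", "known", "first", "only" and "open" are said of these compounds alone.

Of the compounds shown here, three sharing one core have been measured in a functional assay on BGC-823 cells (Homo sapiens) for cytotoxicity, read by MTT assay, with a stated time of 48 h; a lower number here means a stronger inhibitor, a higher number a weaker inhibitor. Compound 1 `Cc1ccc(/C=N/NC(=O)CSc2nnc(-c3ccncc3)o2)cc1` gives 21800 nM, compound 2 `O=C(CSc1nnc(-c2ccncc2)o1)N/N=C/c1cc(Cl)ccc1O` gives 5470 nM, and compound 3 `O=C(CSc1nnc(-c2ccncc2)o1)N/N=C/c1cc(Br)cc(Br)c1O` gives 9610 nM. Compound 3 thus holds the second highest of the three numbers: a 1.8-fold higher number from compound 2 to compound 3 (0.24 log units; within the scatter), whereas a 2.3-fold lower number from compound 1 to compound 3 (0.36 log units; beyond the scatter). Compound 4 `COc1cc(/C=N/NC(=O)CSc2nnc(-c3ccncc3)o2)ccc1O` differs from compound 3 in one place: 4-hydroxy-3-methoxyphenyl in place of 3,5-dibromo-2-hydroxyphenyl on a carbon with a double bond to nitrogen. Within the data shown here, the steps that bear on this both replace the 4-methylphenyl of compound 1: a 4.0-fold lower number from compound 1 to compound 2 (0.60 log units; beyond the scatter) and a 2.3-fold lower number from compound 1 to compound 3 (0.36 log units; beyond the scatter). Among the measured compounds shown here, no measured step covers a methoxy group, and the two hydroxyl-bearing compounds sit within the scatter of each other. For compound 4 the expected step is therefore a 1.2-fold lower number from compound 3 to compound 4 (0.08 log units; within the scatter), not beyond the scatter. In this assay compound 4 is estimated at 8000 nM, between 3000 nM and 22000 nM.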

Compound 4, half-maximal inhibitory concentration: 4320 nM
Estimate against measurement, compound 4: 1.9-fold (0.27 log units) above, and the stated range covers the measured number.
By their numbers in this assay, from the lowest: compounds 4, 2 and 3 (each within the scatter of the next, the first and the last beyond it); then compound 1.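

In this assay, a ring without halogen now matches the halogen-bearing compound 2 at this carbon (a 1.3-fold lower number from compound 2 to compound 4 (0.10 log units; within the scatter)) and improves on compound 3 (a 2.2-fold lower number from compound 3 to compound 4 (0.35 log units; beyond the scatter)). The earlier gains over 4-methylphenyl all came with a halogen, yet this change gives a step of its own (a 5.0-fold lower number from compound 1 to compound 4 (0.70 log units; beyond the scatter)), so among these compounds halogen is not needed for such a gain. No evidence is available that explains these steps. The compounds shown leave open how the hydroxyl and methoxy groups of compound 4 contribute separately. They also leave open how an amine or a carboxylic acid on this ring would fare.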